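The source may hold more compounds than are shown below. What is called first, only, known or untested is meant among the compounds shown, and "the series" means these compounds.

The measured compounds:

Compound 1 `CC(=O)NCc1cccc(Cn2nc(NS(=O)(=O)c3ccc(Cl)s3)c3ccccc32)c1` gives 251 nM in a functional assay on CHO cells for antagonist activity at C-C chemokine receptor type 4 (Homo sapiens), read by GTPgammaS binding; a higher number here means a weaker inhibitor, a lower number a stronger inhibitor.
Compound 2 `CC(=O)NCc1cccc(Cn2nc(NS(=O)(=O)c3ccc(Cl)s3)c3c(F)cccc32)c1` gives 79.4 nM in this assay.
Compound 3 `CC(=O)NCc1cccc(Cn2nc(NS(=O)(=O)c3ccc(Cl)s3)c3c(C#N)cccc32)c1` gives 316 nM in this assay.

Compound 3 and compound 1 give numbers that sit within the scatter of each other: a 1.3-fold higher number from compound 1 to compound 3 (0.10 log units; within the scatter). Compound 2 stands apart from both, since a 3.2-fold lower number from compound 1 to compound 2 (0.50 log units; beyond the scatter) and a 4.0-fold higher number from compound 2 to compound 3 (0.60 log units; beyond the scatter) are each beyond the scatter.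

The next compound, compound 4 `CC(=O)NCc1cccc(Cn2nc(NS(=O)(=O)c3ccc(Cl)s3)c3c(C(C)=O)cccc32)c1`, changes the same position on the shared core once more: acetyl in place of cyano on an aromatic carbon. Within the data shown here, the steps that bear on this are the two already made at that position, a 1.3-fold higher number from compound 1 to compound 3 (0.10 log units; within the scatter), which is within the scatter, and a 4.0-fold higher number from compound 2 to compound 3 (0.60 log units; beyond the scatter), which is modest. Among the measured compounds shown here, no measured step replaces a cyano with an acetyl, so nothing shows directly how the acetyl will behave. Given that the cyano changed little against hydrogen, compound 4 in this assay is expected to show a step of about a 1.1-fold lower number from compound 3 to compound 4 (0.02 log units; within the scatter), that is, no change beyond the scatter. Compound 4 is thus estimated at 300 nM, with a range from 120 nM to 750 nM.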

Compound 4, half-maximal inhibitory concentration: 100 nM
Compound 4: the middle estimate sits 3.0-fold (0.48 log units) above what was measured; measured number outside the range, below it.
By their numbers in this assay, from the lowest: compounds 2 and 4 (each within the scatter of the next); then compounds 1 and 3 (each within the scatter of the next).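

At this position, on an aromatic carbon ortho to a fused ring, the choice between two groups that each carry a hydrogen-bond acceptor clearly matters: acetyl in place of cyano gives a stronger inhibitor (a 3.2-fold lower number from compound 3 to compound 4 (0.50 log units; beyond the scatter)). Acetyl also beats plain hydrogen (a 2.5-fold lower number from compound 1 to compound 4 (0.40 log units; beyond the scatter)) and sits level with fluoro (a 1.3-fold higher number from compound 2 to compound 4 (0.10 log units; within the scatter)), so two of the three groups tried here, fluoro and acetyl, give a gain over hydrogen, while cyano goes against that trend. Nothing available explains why acetyl and cyano part ways at this position.

Going by these compounds, it remains open whether the gain comes from the carbonyl or from the whole acetyl group, which a methyl ester or an amide at this place could help to separate. How a longer chain, such as propanoyl, or an amine would behave here is also unknown.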